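The compounds below may be only part of what the source reports. "The series", "measured", "known", "first", "only" and "open" are said of these compounds alone.

Working notes on the series. Compound 1 `CC(=O)OCc1ccc2oc(=O)c(C(=O)Sc3cccc(Br)c3)cc2c1` and compound 2 `CCCCCC(=O)OCc1ccc2oc(=O)c(C(=O)Oc3cccc(Br)c3)cc2c1` share one core and differ at the link to the bromophenyl group and in the ester chain. In a functional assay on HT-1080 cells (Homo sapiens), read by transwell migration, with a stated time of 24 h, tested at 1 uM (a lower number here means a stronger effect, a higher number a weaker effect of the compound at the concentration tested), compound 1 gives 70.9%, while compound 2 gives 59.3%; compound 2 thus stands with the lower of the two numbers, the stronger effect of the pair, and the gap to compound 1 lies beyond the scatter. Among the compounds with values here, no single-point step between measured compounds is available, so no measured step can be cited.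

Compound 3 `O=C(Oc1cccc(Br)c1)c1cc2cc([N+](=O)[O-])ccc2oc1=O` is the next compound to be measured in this assay. Relative to compound 2 the change is nitro in place of ((pentylcarbonyl)oxy)methyl on an aromatic carbon. Within the data shown here, no measured compound carries this group on the core, so the expectation rests on compound 2 alone. The step from compound 2 is estimated as a number 8.7 percentage points higher from compound 2 to compound 3 (within the scatter), a move toward a weaker effect but one that need not clear the scatter. For compound 3 the estimated read-out in this assay is 68%, with a range from 50% to 86%.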

Compound 3, a percentage reported as activity, at one concentration (the size of the read-out at that concentration, not a potency): 35.2%
Beside the measured number, compound 3's estimate is 32.8 percentage points above it; the whole stated range lies above it.
By their numbers in this assay, from the lowest: compound 3; then compound 2; then compound 1.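

In this assay, nitro in place of ((pentylcarbonyl)oxy)methyl on this aromatic carbon gives a number 24.1 percentage points lower from compound 2 to compound 3 (beyond the scatter) and moves the read-out toward a stronger effect, so this position on the shared core clearly influences the result. The earlier compounds shown here could not show this, as they both carry an ester chain here and differ in more than one place. The ((pentylcarbonyl)oxy)methyl group is therefore not required for an effect at the concentration tested, although no measured evidence accounts for the step.

Within the data shown here, the single step cannot separate a contribution from nitro itself from the loss of the ((pentylcarbonyl)oxy)methyl group, and a plain hydrogen, an amine or a nitrile on the same carbon would help to distinguish the two. On these data alone, whether the step carries over to the sulfur-linked bromophenyl group of compound 1 also stays open, as does whether a shorter ester chain at this position would give a read-out closer to that of compound 2 or to that of compound 3.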